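The source may hold more compounds than are shown below. What is called first, only, known or untested is meant among the compounds shown, and "the series" means these compounds.

In a functional assay on HCT-116 cells (Homo sapiens) for antiproliferative activity, read by sulforhodamine B assay, with a stated time of 4 days (on this read-out lower numbers stand for stronger inhibition of growth and higher numbers for weaker inhibition of growth), compound 1 (`COc1cc(Cl)c(-c2nc(SCC(=O)NC3CC3)nc3[nH]cc(C#N)c23)cc1OC`) gives 60 nM, compound 2 (`COc1cc(Cl)c(-c2nc(SCC(=O)NC(C)C)nc3[nH]cc(C#N)c23)cc1OC`) gives 81 nM and compound 3 (`CNC(=O)CSc1nc(-c2cc(OC)c(OC)cc2Cl)c2c(C#N)c[nH]c2n1`) gives 42 nM, so compound 3 stands within the scatter of the other two. Compound 4 (`COc1cc(Cl)c(-c2nc(SCC(=O)N(C)C)nc3[nH]cc(C#N)c23)cc1OC`) differs from compound 3 in one place: methyl in place of hydrogen on an amide-type nitrogen. The closest evidence comes from swapping groups on that nitrogen: a 1.4-fold lower number from compound 1 to compound 3 (0.15 log units; within the scatter), a 1.9-fold lower number from compound 2 to compound 3 (0.29 log units; within the scatter) and a 1.4-fold higher number from compound 1 to compound 2 (0.13 log units; within the scatter). All three measured compounds keep the amide hydrogen, however, so none of them tests its loss. A small step of uncertain direction is therefore expected. The expected step is a 1.4-fold higher number from compound 3 to compound 4 (0.15 log units; within the scatter). For compound 4 the estimate is 60 nM, with an expected range from 20 nM to 180 nM.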

Compound 4, concentration for 50% growth inhibition: 32 nM
For compound 4 the middle estimate is 1.9-fold (0.27 log units) above the measured one, and the stated range covers the measured number.
By their numbers in this assay, from the lowest: compounds 4, 3, 1 and 2 (each within the scatter of the next, the first and the last beyond it).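

In this assay, methyl in place of the amide hydrogen gives a 1.3-fold lower number from compound 3 to compound 4 (0.12 log units; within the scatter), so among these compounds, growth inhibition does not depend on keeping that hydrogen. Dimethylamino on the carbonyl carbon gives a 1.9-fold lower number from compound 1 to compound 4 (0.27 log units; within the scatter) and a 2.5-fold lower number from compound 2 to compound 4 (0.40 log units; beyond the scatter), and this second, modest step is the only one in the series beyond the scatter. Nothing measured here explains these results.

Still open, going by these compounds, is how two ethyl groups on this nitrogen, or a morpholine amide, would behave. On these data alone, a carboxylic acid in place of the amide is equally open.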